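The source may report more compounds than this note shows. Statements on the series, on what has been measured and on what is new or still open speak of the compounds shown alone.

Within the data shown here, compound 2, with the structure `COc1nc(-c2ccccn2)cc(C(C)(C)C)c1C#N`, gives 850 nM in an assay on isolated protein for inhibition of sulfide:quinone oxidoreductase, mitochondrial (Homo sapiens) (on this read-out lower numbers stand for stronger inhibition and higher numbers for weaker inhibition), and stands highest of the two numbers measured so far; compound 1, `COc1nc(-c2ccccc2)cc(-c2ccc(F)cc2)c1C#N`, gives 25 nM in this assay. Compound 3, `COc1nc(-c2ccccn2)cc(-c2ccc(F)cc2)c1C#N`, has not been measured. The change from compound 2 to compound 3 is 4-fluorophenyl in place of tert-butyl on an aromatic carbon. Since compound 1, which also carries a 4-fluorophenyl, gives 25 nM, a step beyond the scatter toward a lower number is expected, as an 8.5-fold lower number from compound 2 to compound 3 (0.93 log units; beyond the scatter). Compound 3 is estimated at 100 nM, within a range from 30 nM to 400 nM.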

Compound 3, half-maximal inhibitory concentration: 14 nM
Beside the measured number, compound 3's estimate is 7.1-fold (0.85 log units) above it; the measured number lies below the stated range.
By their numbers in this assay, from the lowest: compounds 3 and 1 (each within the scatter of the next); then compound 2.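

In this assay, 4-fluorophenyl in place of tert-butyl on this aromatic carbon gives a 61-fold lower number from compound 2 to compound 3 (1.78 log units; beyond the scatter) and so shows, with pyridin-2-yl held constant, how strongly the number depends on the group at this position. Pyridin-2-yl in place of phenyl, with 4-fluorophenyl held constant, gives a 1.8-fold lower number from compound 1 to compound 3 (0.25 log units; within the scatter) and so makes no clear difference. Nothing measured here explains the large step. Going by these compounds, how an unsubstituted phenyl or a cyclohexyl would compare at this position stays open, and with it whether the fluorine or the aromatic ring accounts for the step.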